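Spiro-oxindole series: methyl on the aryl triazole

The source may hold more compounds than are shown below. What is called first, only, known or untested is meant among the compounds shown, and "the series" means these compounds.

Two spiro-oxindole compounds carry a 4-chlorophenyl on the triazole nitrogen. Compound 1 `N#CC1=C(N)Oc2c(c3nc4ccccc4nc3c3ccccc23)C12C(=O)N(Cc1cnnn1-c1ccc(Cl)cc1)c1ccccc12` and compound 2 `N#CC1=C(N)Oc2c(N)cc3nc4ccccc4nc3c2C12C(=O)N(Cc1cnnn1-c1ccc(Cl)cc1)c1ccccc12` differ in the placement of the amino group on the fused core, and both were tested in a functional assay on HepG2 cells (Homo sapiens) for antiproliferative activity, read by MTT assay, with a stated time of 48 h; a lower number here means a stronger inhibitor, a higher number a weaker inhibitor. Compound 1 gave only a limit, > 50000 nM. Compound 2 likewise gave only a limit, > 50000 nM. Compound 2 therefore stands nowhere on a measurable scale: the limit of > 50000 nM in this assay, at which 2 of the 2 values shown sit, so neither compound shows detectable inhibition within the tested range.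

Compound 3 `Cc1ccc(Cl)cc1-n1nncc1CN1C(=O)C2(C(C#N)=C(N)Oc3c(N)cc4nc5ccccc5nc4c32)c2ccccc21` is the next member, obtained from compound 2 by one change: 5-chloro-2-methylphenyl in place of 4-chlorophenyl on an aromatic nitrogen. The 5-chloro-2-methylphenyl replaces the 4-chlorophenyl on the aromatic nitrogen, with the rest of the molecule, including the amino-bearing core, left as in compound 2. Among the compounds with values here, no measured step between two compounds exists to calibrate what such a replacement does in this assay.

With compound 2 at the reporting limit, > 50000 nM, no movement beyond the scatter is expected, and compound 3 is most likely to return a limit as well. Compound 3 is estimated at 60000 nM, within 20000 nM to 200000 nM, which corresponds to an expected step that the limit leaves unreadable from compound 2 to compound 3.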

Compound 3, half-maximal inhibitory concentration: 17300 nM
The estimate for compound 3 lay 3.5-fold (0.54 log units) above the measured number; measured number below the stated range.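

The aryl group on the aromatic nitrogen is the first place in the compounds shown where a single change registers in this assay: 5-chloro-2-methylphenyl in place of 4-chlorophenyl gives an at least 2.8-fold lower number from compound 2 to compound 3 (0.46 log units; beyond the scatter). Compound 3 thus gives a measured number, 17300 nM, so this position can move the read-out while the amino-bearing core stays unchanged, although the two group names differ in both the added methyl and the placement of the chloro, and this one step does not separate the two. The step can be stated only as a lower bound because compound 2 sits at a limit and not at a number: the limit of > 50000 nM in this assay, at which 2 of the 3 values shown sit.

From the compounds shown here alone, whether the methyl or the placement of the chloro carries the step stays open, and a 2-methylphenyl or 3-chlorophenyl on the same nitrogen would address that directly. Also open, going by these compounds, are whether the same replacement would move the core of compound 1 and how this position responds to a different kind of group, such as a methoxy or a carboxylic acid on the phenyl ring.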